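Benzothiazole ethers in the writhing test: methoxy replaces fluoro

The compounds below may be only part of what the source reports. "The series", "measured", "known", "first", "only" and "open" are said of these compounds alone.

Measured so far:
compound 1, `FC(F)(F)c1ccc(COc2nc3ccccc3s2)cc1`, 99.6%
compound 2, `O=[N+]([O-])c1ccc(COc2nc3ccccc3s2)cc1`, 97%
compound 3, `Fc1ccc(COc2nc3ccccc3s2)cc1`, 51.9%

In a functional assay on the whole organism with Mus musculus as the target, in the writhing test, at a dose of 100 mg/kg by the intraperitoneal route (on this read-out lower numbers stand for less inhibition and higher numbers for more inhibition at the one dose given (going by the name of the read-out)), compound 1 gives 99.6% and compound 2 gives 97%, two values that lie within the scatter of each other, as the step of a number 2.6 percentage points lower from compound 1 to compound 2 (within the scatter) shows. Compound 3, with fluoro on the aromatic carbon, stands lowest of the three at 51.9%; the steps of a number 47.7 percentage points lower from compound 1 to compound 3 (beyond the scatter) and a number 45.1 percentage points lower from compound 2 to compound 3 (beyond the scatter) are both large and beyond the scatter, so compound 3 stands clearly apart from the other two.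

Compound 4, `COc1ccc(COc2nc3ccccc3s2)cc1`, has not been measured. Its difference from compound 3 is methoxy in place of fluoro on an aromatic carbon, on an aromatic carbon of the six-membered carbon ring. Among the compounds with values here, no measured step involves methoxy; the two large steps into compound 3 only show that fluoro gives much less inhibition than trifluoromethyl or nitro at this position. They therefore bear on compound 4 only indirectly: the place itself is one where the group matters a great deal, but the direction for methoxy is not fixed by any comparison shown. Compound 4 is expected to give 62% with a range of 30% to 92%, a step of a number 10.1 percentage points higher from compound 3 to compound 4 (beyond the scatter) that is expected only loosely. The expectation is loose since the anchors are far apart: compound 1 gives 99.6%, compound 2 gives 97% and compound 3 gives 51.9%, and these three values span nearly the whole scale.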

Compound 4, a percentage reported as inhibition, in the whole organism at one dose (the size of the read-out at that dose, not a potency): "not active" (no number reported)
Nothing numeric was reported for compound 4; the estimate stays without a comparison.
By their numbers in this assay, from the lowest: compound 3; then compounds 2 and 1 (each within the scatter of the next).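

In this assay, within the data shown here, compound 4 is reported only as not active, without a number, so no step from compound 3 to compound 4, or from compound 1 or compound 2 to compound 4, can be read. The compounds shown leave open how much inhibition, if any, methoxy allows at this place. No measurement shown offers an explanation for this result.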